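The compounds below may be only part of what the source reports. "The series", "measured", "known", "first", "only" and "open" are said of these compounds alone.

Values in a functional assay on HT cells (Homo sapiens) for antiproliferative activity, read by fluorescence, with a stated time of 72 h; a higher number here means a weaker inhibitor of growth, a lower number a stronger inhibitor of growth:
- compound 1 `CC(C)c1n[nH]c2c(NCc3ccc(-c4ccccn4)cc3)nc(SCC(O)C(F)(F)F)nc12`: 690 nM
- compound 2 `CC(C)c1n[nH]c2c(NCc3ccc(-c4ccccn4)cc3)nc(SC3CCCC3O)nc12`: 567 nM

Compound 2, at 567 nM, stands level with compound 1, and the two numbers cannot be separated: a 1.2-fold lower number from compound 1 to compound 2 (0.09 log units; within the scatter).

Compound 3 `CC(C)c1n[nH]c2c(NCc3ccc(-c4ccccn4)cc3)nc(SCC(N)=O)nc12` keeps the shared core and changes only the group on the sulfur, with carbamoylmethyl in place of 2-hydroxycyclopentyl on a sulfur. The ring of compound 2 is lost, and the incoming group brings a double bond outside aromatic rings.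

Going by the values given here, only one measured step bears on this change. It replaces one group on the same sulfur by another, and its size stays within the scatter: a 1.2-fold lower number from compound 1 to compound 2 (0.09 log units; within the scatter). Among the compounds with values here, that step offers limited guidance, since no measured compound carries carbamoylmethyl and the series holds just two numbers. No direction can be argued firmly, so no shift beyond the scatter is expected in this assay. The expected change is a 1.2-fold higher number from compound 2 to compound 3 (0.09 log units; within the scatter). For compound 3 the estimated value is 700 nM, with an expected range of 250 nM to 2000 nM.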

Compound 3, concentration for 50% growth inhibition: 192 nM
Compound 3: middle estimate off by 3.6-fold (0.56 log units), on the high side; the whole stated range lies above it.
By their numbers in this assay, from the lowest: compound 3; then compounds 2 and 1 (each within the scatter of the next).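

In this assay the group on the sulfur can move the number beyond the scatter, which the step between compound 1 and compound 2 did not show, and carbamoylmethyl gives the lowest number of the series against both earlier groups (a 3.0-fold lower number from compound 2 to compound 3 (0.47 log units; beyond the scatter)) and (a 3.6-fold lower number from compound 1 to compound 3 (0.56 log units; beyond the scatter)). Compound 1 also carries an open chain with no ring on the sulfur yet stands within the scatter of compound 2, so losing the ring does not by itself go with the lower number, and the shift appears only in the compound with a double bond outside aromatic rings. No measured data accompany these numbers that would explain the shift.

The compounds shown do not separate the contribution of the amide from that of the size of the group on the sulfur. A carboxylic acid, a methyl ester or a longer chain ending in the same amide, placed on this sulfur, would bear on whether the lower number depends on the amide itself or on its distance from the sulfur.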